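The source may hold more compounds than are shown below. What is called first, only, known or untested is meant among the compounds shown, and "the series" means these compounds.

Among the compounds with values here, in a functional assay on MKN-45 cells (Homo sapiens) for antiproliferative activity, read by MTT assay, with a stated time of 72 h (a higher number here means a weaker inhibitor, a lower number a stronger inhibitor), compound 1, `COc1cc(CCc2cccc(Cl)c2Cl)cc(OC)c1O`, gives 11 nM, which is the lowest of the two numbers measured so far. Within the data shown here, the only other measured compound, compound 2, `COc1cc(CCc2cccc(F)c2)cc(OC)c1O`, gives 2970 nM in this assay, a much higher number, so compound 1 is the stronger inhibitor of the pair by a margin well beyond the usual scatter.

The next compound, compound 3, `COc1cc(CCc2ccccc2Cl)cc(OC)c1O`, has not yet been measured. It differs from compound 1 in a single place: hydrogen in place of chloro on an aromatic carbon. One of the two chloro groups on the ring at the end of the chain is gone; the other chloro group stays. Among the measured compounds shown here, no pair of measured compounds shows the effect of exactly this change, so the size of the step is uncertain. For the measured compounds named here, since compound 2 gives 2970 nM in this assay while carrying only a single fluoro on that ring, a weaker inhibitor than compound 1 is expected, though not as weak as compound 2. The expected step from removing the chloro group is a 14-fold higher number from compound 1 to compound 3 (1.13 log units; beyond the scatter). For compound 3 the estimate in this assay is 150 nM, within a range from 30 nM to 1500 nM.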

Compound 3, half-maximal inhibitory concentration: 24500 nM
The estimate for compound 3 lay 160-fold (2.21 log units) below the measured number; measured number above the stated range.
By their numbers in this assay, from the lowest: compound 1; then compound 2; then compound 3.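

Removing one chloro group, the one on an aromatic carbon ortho to a chloro group and meta to a large group, gives a 2200-fold higher number from compound 1 to compound 3 (3.35 log units; beyond the scatter) in this assay as a large step beyond the scatter. Within the data shown here, this is the first direct reading of this position: compound 1 and compound 2 differ in more than one place and so could not isolate this chloro group, whereas here the exchange of a single heavy atom for hydrogen separates the two compounds, and the chloro group that stays does not keep the number of compound 1 on its own. Nothing available here explains why this one exchange has so large an effect.

The compounds shown leave open whether chloro itself is needed on this carbon or whether another group, such as bromo, methyl or methoxy, would serve there equally well. They also leave open what would happen if the other chloro group were replaced by hydrogen while this one stayed in place.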